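The compounds below may be only part of what the source reports. "The series", "measured", "known", "first", "only" and "open" are said of these compounds alone.

Compound 1 `Cn1ncc2c(NC(=O)NCc3cc(C(F)(F)F)nn3-c3ccc(C(C)(C)C)cc3)cccc21` gives 13.2 nM in an assay on CHO-K1 cells for antagonist activity at transient receptor potential cation channel subfamily V member 1 (Homo sapiens), read by FLIPR and calcium flux, with a stated time of 6 min; a higher number here means a weaker inhibitor, a lower number a stronger inhibitor. Compound 2 `Cn1ncc2c(NC(=O)NCc3cc(C(F)(F)F)nn3-c3ccc(F)c(F)c3)cccc21` differs from it only by 3,4-difluorophenyl in place of 4-(tert-butyl)phenyl on an aromatic nitrogen and in this assay compound 2 gives 4.9 nM, so that a 2.7-fold lower number from compound 1 to compound 2 (0.43 log units; beyond the scatter). Compound 3 `Cn1ncc2c(NC(=O)NCc3cc(C(C)(C)C)nn3-c3ccc(C(C)(C)C)cc3)cccc21` carries the other core, the difference being (tert-butyl in place of trifluoromethyl on an aromatic carbon); in this assay compound 3 gives 46.3 nM, which is a 3.5-fold higher number from compound 1 to compound 3 (0.55 log units; beyond the scatter), the highest number of the three measured. Compound 4 `Cn1ncc2c(NC(=O)NCc3cc(C(C)(C)C)nn3-c3ccc(F)c(F)c3)cccc21` has not yet been measured. It relates to compound 3 as compound 2 relates to compound 1, through (3,4-difluorophenyl in place of 4-(tert-butyl)phenyl on an aromatic nitrogen). This is the same kind of change, not the same change, since here the place lies two ring bonds from the ring atom that bears a tert-butyl group rather than a trifluoromethyl group. Because a 2.7-fold lower number from compound 1 to compound 2 (0.43 log units; beyond the scatter), compound 4 is expected to show a 2.6-fold lower number from compound 3 to compound 4 (0.41 log units; beyond the scatter) in this assay. The estimate for compound 4 in this assay is 18 nM, expected to fall between 8 nM and 40 nM.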

Compound 4, inhibition constant: 1 nM
The estimate for compound 4 lay 18-fold (1.26 log units) above the measured number; measured number outside the range, below it.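

In this assay, 3,4-difluorophenyl in place of 4-(tert-butyl)phenyl gave a 46-fold lower number from compound 3 to compound 4 (1.67 log units; beyond the scatter), so the direction carried over from the other core but the size did not: the same change on two cores in this assay, a 2.7-fold lower number (0.43 log units; beyond the scatter) from compound 1 to compound 2 and a 46-fold lower number (1.67 log units; beyond the scatter) from compound 3 to compound 4, 17-fold (1.24 log units) apart, beyond the scatter of two such steps. Tert-butyl in place of trifluoromethyl gave a 4.9-fold lower number from compound 2 to compound 4 (0.69 log units; beyond the scatter), a direction opposite to that of the same change on the core bearing 4-(tert-butyl)phenyl: the same change on two cores in this assay, a 3.5-fold higher number (0.55 log units; beyond the scatter) from compound 1 to compound 3 and a 4.9-fold lower number (0.69 log units; beyond the scatter) from compound 2 to compound 4, 17-fold (1.24 log units) apart, beyond the scatter of two such steps. The two changes therefore do not act independently in these four compounds, and a step taken from one core did not give the size of the step on the other, though these data do not show why this happens or whether it extends beyond them.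

The compounds shown leave open whether the same dependence appears with a cyclopropyl group or a chlorine atom on the aromatic carbon now bearing tert-butyl or trifluoromethyl. They also leave open how a 4-fluorophenyl or a 4-chlorophenyl group would behave on the aromatic nitrogen.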